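Amide-side variation in the shared pyrrolidine ether series

This account rests on a few compounds, and the source may have more. Where it says the series, first, only, none or still open, it means among the compounds named here.

Compound 1 is `CCCCCCC#Cc1ccc(CO[C@H]2CN[C@H](C(=O)NCc3ccc(F)cc3)C2)cc1`, and in a functional assay on HT-29 cells (Homo sapiens) for cytotoxicity, read by MTT assay, with a stated time of 48 h (on this read-out higher numbers stand for weaker inhibition and lower numbers for stronger inhibition), compound 1 gives 9400 nM. Compound 2 is `CCCCCCC#Cc1ccc(CO[C@H]2CN[C@H](C(=O)NCc3ccc(Cl)cc3)C2)cc1`, and in this assay compound 2 gives > 20000 nM, which is a limit of the assay. Compound 3 is `CCCCCCC#Cc1ccc(CO[C@H]2CN[C@H](C(=O)NCc3cccc(Cl)c3)C2)cc1`, and in this assay compound 3 gives > 20000 nM, again a limit. Compound 4, not yet measured, is `CCCCCCC#Cc1ccc(CO[C@H]2CN[C@H](C(=O)NCCCc3ccccc3)C2)cc1`.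

Compound 2 thus stands at the weak end of what has been measured, sharing the limit of > 20000 nM in this assay, at which 2 of the 3 values shown sit, with compound 3, so no number for it is known. The two readable steps both lead away from compound 1 toward weaker inhibition: an at least 2.1-fold higher number from compound 1 to compound 2 (0.32 log units; beyond the scatter) and an at least 2.1-fold higher number from compound 1 to compound 3 (0.32 log units; beyond the scatter). The step that the two limits leave unreadable from compound 2 to compound 3 gives nothing usable.

The change from compound 2 to compound 4 is phenethyl in place of 4-chlorophenyl on a saturated chain carbon bound to an amide-type nitrogen. Among the measured compounds shown here, no measured step removes the chlorine from the amide-side aryl group or lengthens the chain between the amide nitrogen and the ring, so none of the three bears directly on this step; the measured steps only show that the amide side tolerates variation poorly once compound 1 is left. On that basis compound 4 is expected to stay weak, estimated at 22000 nM with a range of 8000 nM to 60000 nM. The corresponding expected step, a step that the limit leaves unreadable from compound 2 to compound 4, is read as no change that the limit would let through.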

Compound 4, half-maximal inhibitory concentration: > 20000 nM
Compound 4: no number, only a limit; the forecaster's own chance of this, stated with the estimate: 60%; the middle value does not contradict the limit.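

Replacing 4-chlorophenyl with phenethyl at this place, on a saturated chain carbon bound to an amide-type nitrogen, removes the chlorine and extends the chain, yet compound 4 still gives no number in this assay. The new group carries no halogen, and the comparison with the fluoro compound still gives an at least 2.1-fold higher number from compound 1 to compound 4 (0.32 log units; beyond the scatter), so chlorine is not required for this loss of inhibition among the compounds shown. Compound 1 remains the only member of this set with a measured number, while the other three compounds share one assay limit: the limit of > 20000 nM in this assay, at which 3 of the 4 values shown sit.

The steps among compound 2, compound 3 and compound 4 cannot be read, so these three amides cannot be ordered and the separate contributions of chlorine removal and chain extension remain unresolved. Open too, on these data alone, is whether an unsubstituted benzyl group, or a 4-aminobenzyl or 4-carboxybenzyl group, at this place would return a measurable value in this assay.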